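Bromo to Methoxy at the Assay Limit

The compounds below may be only part of what the source reports. "The series", "measured", "known", "first", "only" and "open" are said of these compounds alone.

Compound 1 `C=C1C[C@]23C[C@@]1(O)CC[C@H]2c1ccc(OS(=O)(=O)c2ccc(C)cc2)c(C)c1[C@@H]3Cn1cc(-c2ccc(Cl)cc2)nn1`: > 20000 nM
Compound 2 `C=C1C[C@]23C[C@@]1(O)CC[C@H]2c1ccc(OS(=O)(=O)c2ccc(C)cc2)c(C)c1[C@@H]3Cn1cc(-c2ccc(Br)cc2)nn1`: > 20000 nM

In a functional assay on A549 cells (Homo sapiens) for cytotoxicity, read by MTT assay, with a stated time of 4 days (a higher number here means a weaker inhibitor, a lower number a stronger inhibitor), compound 1 gives > 20000 nM, which is a limit of the assay and not a number. Compound 2 gives > 20000 nM, likewise a limit. The step that the two limits leave unreadable from compound 1 to compound 2 is therefore unreadable. Going by the values given here, compound 2 stands at the limit, and the only other value shown sits there too, as does everything measured so far (the limit of > 20000 nM in this assay, at which 2 of the 2 values shown sit).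

Compound 3 `C=C1C[C@]23C[C@@]1(O)CC[C@H]2c1ccc(OS(=O)(=O)c2ccc(C)cc2)c(C)c1[C@@H]3Cn1cc(-c2ccc(OC)cc2)nn1` differs from compound 2 by methoxy in place of bromo on an aromatic carbon. Among the compounds with values here, no measured step touches this change; the single step from compound 1 to compound 2 concerns a different group and is unreadable in size, so it gives no direction. With both measured compounds at the limit, compound 3 is expected to give 25000 nM, within a range from 8000 nM to 80000 nM. The estimated step that the limit leaves unreadable from compound 2 to compound 3 is expected to show nothing beyond the scatter.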

Compound 3, half-maximal inhibitory concentration: > 20000 nM
Compound 3 gave a limit, no number (the forecaster's own chance of this, stated with the estimate: 75%); the middle value lies beyond the limit too.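

Compound 3 joins compound 1 and compound 2 at the limit, so no step among these three compounds can be read: the limit of > 20000 nM in this assay, at which 3 of the 3 values shown sit.

The compounds shown leave open whether chloro, bromo and methoxy differ at all in this cytotoxicity read-out, since none of the three has given a number.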